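Methyl position on the pendant phenyl

The compounds below may be only part of what the source reports. "The series", "measured", "known", "first", "only" and "open" are said of these compounds alone.

Compound 3 `Cc1ccccc1-c1ccccc1OC(C)C1=NCCN1` gives 832 nM in an assay on CHO cells for displacement of a labelled ligand from Alpha-2B adrenergic receptor (Homo sapiens) (on this read-out lower numbers stand for stronger inhibition and higher numbers for weaker inhibition), and stands second highest of the three numbers. Compound 2 `CC(Oc1ccccc1-c1cccnc1)C1=NCCN1` gives 933 nM, and the difference a 1.1-fold lower number from compound 2 to compound 3 (0.05 log units; within the scatter) lies within the scatter. Compound 1 `Cc1ccc(-c2ccccc2OC(C)C2=NCCN2)cc1` gives 398 nM, the lowest number of the three; the step of a 2.1-fold higher number from compound 1 to compound 3 (0.32 log units; beyond the scatter) is modest but beyond the scatter. Compound 4 `Cc1cccc(-c2ccccc2OC(C)C2=NCCN2)c1` differs from compound 3 by 3-methylphenyl in place of 2-methylphenyl on an aromatic carbon. Among the measured compounds shown here, the only step that bears on shifting the methyl around the pendant phenyl is the one from compound 1 to compound 3, and it was modest. Compound 4 is therefore expected to show a small step down in this assay, a 1.5-fold lower number from compound 3 to compound 4 (0.18 log units; within the scatter). The estimate for compound 4 is 550 nM, with a range from 250 nM to 1200 nM.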

Compound 4, inhibition constant: 537 nM
Compound 4: the middle estimate sits 1.0-fold (0.01 log units) above what was measured, and the stated range covers the measured number.
By their numbers in this assay, from the lowest: compounds 1, 4, 3 and 2 (each within the scatter of the next, the first and the last beyond it).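

In this assay the 3-methylphenyl group cannot be separated from any of the other groups at this place, since the steps of a 1.5-fold lower number from compound 3 to compound 4 (0.19 log units; within the scatter) and a 1.3-fold higher number from compound 1 to compound 4 (0.13 log units; within the scatter) and a 1.7-fold lower number from compound 2 to compound 4 (0.24 log units; within the scatter) all lie within the scatter. Among the three methylphenyl groups, the only step beyond the scatter remains a 2.1-fold higher number from compound 1 to compound 3 (0.32 log units; beyond the scatter) and compound 4 falls within the scatter of both of these compounds, so no graded order by methyl position can be read. No supporting data bear on these small differences.

On these data alone, whether a larger change on the pendant ring, such as a carboxylic acid, an amine or a methoxy group in place of the methyl, would give a step clearly beyond the scatter stays open.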